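The source may report more compounds than this note shows. Statements on the series, on what has been measured and on what is new or still open speak of the compounds shown alone.

Measured compounds in a functional assay on CHO cells for agonist activity at adenosine receptor A1 (Homo sapiens), read by fluorescence and ERK phosphorylation, with stated times of 30 min and 1.5 h, tested at 3 uM; a lower number here means a weaker effect, a higher number a stronger effect of the compound at the concentration tested:
Compound 1 `Nc1scc(-c2ccccc2F)c1C(=O)c1ccccc1` gives 55%.
Compound 2 `Nc1scc(-c2ccc(F)cc2)c1C(=O)c1ccccc1` gives 51%.
Compound 3 `Nc1scc(-c2cccc(Cl)c2)c1C(=O)c1ccccc1` gives 45%.

Compound 2 stands second highest of these three numbers; the nearest step is a number 4 percentage points lower from compound 1 to compound 2 (within the scatter) and the furthest is a number 6 percentage points lower from compound 2 to compound 3 (within the scatter). Both steps fall within the scatter, so the three measured compounds are not separated from one another in this assay.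

Compound 4 `COc1ccc(-c2csc(N)c2C(=O)c2ccccc2)cc1` has not yet been measured. It differs from compound 2 in one place: methoxy in place of fluoro on an aromatic carbon. The measured steps that bear on this change are those that also alter the group on the same six-membered aromatic ring of carbon only: a number 4 percentage points lower from compound 1 to compound 2 (within the scatter), a number 10 percentage points lower from compound 1 to compound 3 (within the scatter) and a number 6 percentage points lower from compound 2 to compound 3 (within the scatter). Among the measured compounds shown here, none of them moved the read-out beyond the scatter, and no measured compound carries methoxy at this place. On that basis the expected step is a number 1 percentage points lower from compound 2 to compound 4 (within the scatter), with no change beyond the scatter anticipated. Compound 4 is therefore estimated to give about 50% in this assay, within a range from 32% to 68%.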

Compound 4, a percentage reported as activity, at one concentration (the size of the read-out at that concentration, not a potency): 52%
Compound 4: middle estimate off by 2 percentage points, on the low side; the measured number falls inside the stated range.
By their numbers in this assay, from the lowest: compounds 3, 2, 4 and 1 (each within the scatter of the next).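

In this assay the change from fluoro to methoxy, on an aromatic carbon para to a large group, gives a step of a number 1 percentage points higher from compound 2 to compound 4 (within the scatter). The earlier compounds shown here varied only a halogen and its place on this ring, whereas compound 4 carries a group with carbon and oxygen, two heavy atoms instead of one and a hydrogen-bond acceptor that fluoro is not counted as having, and the read-out still stays level with that of compound 2. No measurement is available that would explain why these two groups read alike.

As far as these compounds go, whether an amine, a carboxylic acid or a longer chain such as butoxy at this place would also stay within the scatter remains open. From the compounds shown here alone, the read-out also gives the size of the effect at a single concentration, so any difference in potency between compound 2 and compound 4 is unknown.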